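The source may report more compounds than this note shows. Statements on the series, on what has been measured and on what is new or still open speak of the compounds shown alone.

Compound 1 `O=C(CCc1ccc(-c2ccccc2Cl)cc1)N1CCCC1` gives > 100000 nM in an assay on HEK293 cells for inhibition of N-acylethanolamine-hydrolyzing acid amidase (Rattus norvegicus), read by LC-MS, with a stated time of 30 min (a higher number here means a weaker inhibitor, a lower number a stronger inhibitor), which is a limit of the assay and not a number.
Compound 2 `O=C(CCc1ccc(-c2ccccn2)cc1)N1CCCC1` gives > 100000 nM in this assay, again a limit of the assay rather than a measured number.

Among the measured compounds shown here, compound 2 therefore stands only at a limit in this assay, and the one further value shown for this series is also a limit, as the limit of > 100000 nM in this assay, at which 2 of the 2 values shown sit, records. For the measured compounds named here, the single step between measured compounds, a step that the two limits leave unreadable from compound 1 to compound 2, runs between two limits and its size cannot be read.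

Compound 3 `O=C(CCc1ccc(C2CCCCC2)cc1)N1CCCC1` differs from compound 2 in one place: cyclohexyl in place of pyridin-2-yl on an aromatic carbon. Going by the values given here, no measured step speaks readably to this exchange, since the only step available, a step that the two limits leave unreadable from compound 1 to compound 2, is unreadable in both size and direction. With the shared core of compound 1 and compound 2 giving nothing but limits in this assay, compound 3 is expected to stay in the same weak region, and the step that the limit leaves unreadable from compound 2 to compound 3 is estimated to be small or absent beyond the scatter. Compound 3 is therefore estimated at 150000 nM in this assay, with a range from 30000 nM to 1000000 nM, and most likely only a limit will again be reported.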

Compound 3, half-maximal inhibitory concentration: 500 nM
Beside the measured number, compound 3's estimate is 300-fold (2.48 log units) above it; the whole stated range lies above it.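

In this assay, among the compounds shown here, the place on an aromatic carbon, para to a group of 9 heavy atoms, now turns out to govern the read-out, which the earlier compounds could not show: cyclohexyl in place of pyridin-2-yl gives an at least 200-fold lower number from compound 2 to compound 3 (2.30 log units; beyond the scatter), and cyclohexyl in place of 2-chlorophenyl gives an at least 200-fold lower number from compound 1 to compound 3 (2.30 log units; beyond the scatter). Pyridin-2-yl and cyclohexyl both hold 6 heavy atoms, so the count of heavy atoms does not separate them, and the exchange replaces an aromatic ring with 1 hetero atom by a non-aromatic ring of carbon only. The full size of both steps stays unknown, since each starts from a limit of the assay: the limit of > 100000 nM in this assay, at which 2 of the 3 values shown sit.

The step between compound 1 and compound 2 cannot be read, and the compounds shown do not tell whether the large change follows from losing the aromatic ring or the ring nitrogen, a question that a plain phenyl group would help to separate. From the compounds shown here alone, how cyclopentyl, piperidin-4-yl or an open chain such as hexyl would fare at this place on the shared core also remains open.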